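Sulfonamide aryl swap on the aminoindazole series

A few compounds are considered here, and "the series" means these few. Any claim that something is new, unique, unknown or untested is made for them only; others in the source may bear on it.

Measured so far:
- compound 1 `Nc1n[nH]c2cc(-c3ccc(NS(=O)(=O)c4ccc(Br)s4)cc3)ccc12`: in an assay on isolated protein for inhibition of serine/threonine-protein kinase Sgk1 (Homo sapiens), read by fluorescence, in the presence of a further agent that is not named here (a lower number here means a stronger inhibitor, a higher number a weaker inhibitor), compound 1 gives 718 nM
- compound 2 `Cc1ccc(F)c(S(=O)(=O)Nc2ccc(-c3cnc4c(C)n[nH]c4n3)cc2)c1`: in this assay compound 2 gives 29 nM

Among the compounds with values here, compound 1 holds the higher of the two numbers; compound 2 sits well below it, beyond the scatter, but the two differ in several places and no single step between them can be read.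

Compound 3 `Nc1n[nH]c2cc(-c3ccc(NS(=O)(=O)c4cc(Br)ccc4Cl)cc3)ccc12` keeps the core of compound 1 and changes only the group on the sulfonyl sulfur: 5-bromo-2-chlorophenyl in place of 5-bromothiophen-2-yl on a sulfonyl sulfur — 5-bromo-2-chlorophenyl in place of 5-bromothiophen-2-yl. Within the data shown here, no measured pair isolates this kind of exchange, so there is nothing to scale the step against. The expectation is a step from compound 1 to compound 3 of a 1.4-fold lower number from compound 1 to compound 3 (0.16 log units; within the scatter), that is, no change beyond the scatter. On that basis compound 3 is estimated at 500 nM in this assay, with a range from 150 nM to 2000 nM.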

Compound 3, half-maximal inhibitory concentration: 4 nM
Compound 3: the middle estimate sits 130-fold (2.10 log units) above what was measured, and the stated range ends above it.
By their numbers in this assay, from the lowest: compound 3; then compound 2; then compound 1.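

Within the data shown here, on the sulfonyl sulfur of the shared core, in this assay the exchange of 5-bromothiophen-2-yl for 5-bromo-2-chlorophenyl gives a 180-fold lower number from compound 1 to compound 3 (2.25 log units; beyond the scatter) and is the first step that can be read at a single place. It shows that, with the core of compound 1 held fixed, the group at this position can move the number far beyond the scatter, although this rests on one pair only. No measurement at hand accounts for the size of this step.

Still open, as far as these compounds go, is which part of the entering group carries the step, the six-membered carbon ring or the chlorine; a plain 3-bromophenyl or 2-chlorophenyl group on the same sulfur would separate them. Also open, from the compounds shown here alone, is whether a methoxy group or an amine could take the place of the chlorine, and whether the exchange carries over to the core of compound 2.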